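A few compounds are considered here, and "the series" means these few. Any claim that something is new, unique, unknown or untested is made for them only; others in the source may bear on it.

In an ADME assay on HepG2 cells (Homo sapiens) for cytotoxicity, with a stated time of 72 h (a higher number here means that more compound is needed for the effect, a lower number that less compound is needed), three compounds that share one core have been measured so far. Compound 1 `CCc1ccc(NC(=O)Nc2cc(C)nc3ccccc23)cc1` gives 17000 nM, and compound 2 `CC(=O)c1ccc(NC(=O)Nc2cc(C)nc3ccccc23)cc1` gives 19000 nM. Compound 3 `Cc1cc(NC(=O)Nc2ccc(N)cc2)c2ccccc2n1` gives > 25000 nM, which is a limit of the assay and not a number. That places compound 3 at the limit of > 25000 nM in this assay, at which 1 of the 3 values shown sits.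

Compound 4 `COc1ccc(NC(=O)Nc2cc(C)nc3ccccc23)cc1` carries methoxy in place of the amino group of compound 3, on an aromatic carbon para to a large group: methoxy in place of amino on an aromatic carbon.

The three measured steps all exchange the group at this same place, so they are the closest guide. They are a 1.1-fold higher number from compound 1 to compound 2 (0.05 log units; within the scatter), an at least 1.4-fold higher number from compound 1 to compound 3 (0.16 log units; that floor lies within the scatter) and an at least 1.3-fold higher number from compound 2 to compound 3 (0.11 log units; that floor lies within the scatter). None of them shows a change beyond the scatter, although the last two rest on a limit. No step beyond the scatter is therefore expected here, and no direction is favoured.

The expected step is an at least 1.2-fold lower number from compound 3 to compound 4 (0.09 log units; that floor lies within the scatter). The estimate for compound 4 is 20000 nM, with an expected range from 11000 nM to 32000 nM.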

Compound 4, half-maximal effective concentration: > 25000 nM
Compound 4: a limit, no number (the forecaster's own chance of this, stated with the estimate: 30%); middle value at least 1.2-fold (0.09 log units) away from the limit.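

In this assay compound 4 stands at a limit of the assay and not at a number, so methoxy now joins amino as a second group at this place that ends there: the limit of > 25000 nM in this assay, at which 2 of the 4 values shown sit.

Against the two compounds with numbers, the steps are an at least 1.3-fold higher number from compound 2 to compound 4 (0.11 log units; that floor lies within the scatter) and an at least 1.4-fold higher number from compound 1 to compound 4 (0.16 log units; that floor lies within the scatter), while the step between the two compounds at the limit cannot be read. Methoxy, with no hydrogen-bond donor, thus reaches the same limit as amino, which has one, and no readable step among ethyl, acetyl, amino and methoxy goes beyond the scatter.

Where the true values of compound 3 and compound 4 lie, and whether they differ at all, stays open. So does whether a carboxylic acid, a chlorine atom or a longer chain at this place would bring a step beyond the scatter.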